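This account rests on a few compounds, and the source may have more. Where it says the series, first, only, none or still open, it means among the compounds named here.

Compound 1, `COc1cc2cc(Oc3ccc(NC(=O)Nc4ccc(C(F)(F)F)cc4)cc3)c(C)nc2cc1OC`, gives 56% in a functional assay on SF-295 cells (Homo sapiens) for inhibition, read by sulforhodamine B assay, with a stated time of 48 h, tested at 10 uM; a lower number here means a stronger effect, a higher number a weaker effect of the compound at the concentration tested.
Compound 2, `COc1cc2cc(Oc3ccc(NC(=O)Nc4cccc(C(F)(F)F)c4)cc3)c(C)nc2cc1OC`, gives -15.1% in this assay.

Among the compounds with values here, compound 2 stands lowest of the two numbers measured so far; its nearest neighbour is compound 1, and the step of a number 71.1 percentage points lower from compound 1 to compound 2 (beyond the scatter) lies beyond the scatter. Compound 3, `COc1cc2cc(Oc3ccc(NC(=O)Nc4ccc(Cl)c(Cl)c4)cc3)c(C)nc2cc1OC`, has not yet been measured. Compared with compound 2 the change is 3,4-dichlorophenyl in place of 3-(trifluoromethyl)phenyl on an amide-type nitrogen. Within the data shown here, the only measured step, a number 71.1 percentage points lower from compound 1 to compound 2 (beyond the scatter), concerns a change of where the trifluoromethyl group sits on the phenyl ring, not an exchange of that group for two chlorine atoms, so it bears on the present step only loosely: it shows that the substitution pattern on this phenyl ring can move the read-out a great deal, but it gives no direction for the exchange at hand. The expected step is therefore a number 15.1 percentage points higher from compound 2 to compound 3 (beyond the scatter), a modest rise, with wide uncertainty. Compound 3 is accordingly estimated at 0%, in the range -40% to 50%.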

Compound 3, a percentage reported as activity, at one concentration (the size of the read-out at that concentration, not a potency): 0.69%
For compound 3 the middle estimate is 0.7 percentage points below the measured one; the measured number falls inside the stated range.
By their numbers in this assay, from the lowest: compound 2; then compound 3; then compound 1.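

In this assay, the exchange of 3-(trifluoromethyl)phenyl for 3,4-dichlorophenyl on the amide-type nitrogen gives a number 15.8 percentage points higher from compound 2 to compound 3 (beyond the scatter), while the exchange of 4-(trifluoromethyl)phenyl for the same group gives a number 55.3 percentage points lower from compound 1 to compound 3 (beyond the scatter), so the new compound lies much nearer to compound 2 than to compound 1. This shows that the strong effect at this position is not confined to a phenyl ring carrying trifluoromethyl, since a ring carrying two chlorine atoms in its place keeps most of it, and that the weak read-out of the 4-(trifluoromethyl)phenyl compound does not carry over to 3,4-dichlorophenyl. Nothing shown here offers an explanation for these differences.

Compound 3 brings in both chlorine atoms at once, so the compounds shown cannot tell what each contributes, and a 3-chlorophenyl or a 4-chlorophenyl group on the same nitrogen would be needed to separate them. Going by these compounds, it also remains open how this position responds to a phenyl ring carrying something other than halogen, such as a methoxy group, an amine or a carboxylic acid.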